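A longer chain on compound 1

A few compounds are considered here, and "the series" means these few. Any claim that something is new, unique, unknown or untested is made for them only; others in the source may bear on it.

Going by the values given here, in a functional assay on HCT-116 cells (Homo sapiens) for inhibition, read by MTT assay, with a stated time of 72 h (on this read-out lower numbers stand for stronger inhibition and higher numbers for weaker inhibition), compound 1 (`Nc1nc2cc(-c3nn(CCCC(=O)NO)c4ncnc(N)c34)ccc2o1`) gives 19600 nM as the only true number so far. Compound 2 (`Nc1ncnc2c1c(-c1cnc3[nH]ccc3c1)nn2CCC(=O)NO`) stands at > 150000 nM in this assay and this is a limit, not a number. Compound 3 (`Nc1nc2cc(-c3nn(CCCCCC(=O)NO)c4ncnc(N)c34)ccc2o1`) keeps the core of compound 1 and changes only the chain (2-(hydroxycarbamoyl)ethyl in place of hydroxycarbamoyl on a saturated chain carbon, three bonds along the chain from an aromatic nitrogen), so that 3-(hydroxycarbamoyl)propyl becomes 5-(hydroxycarbamoyl)pentyl. Among the compounds with values here, no measured step guides this change, yet a lower number, beyond the usual scatter, is expected in this assay (a 6.5-fold lower number from compound 1 to compound 3 (0.82 log units; beyond the scatter)). Compound 3 is estimated at 3000 nM with an expected range of 400 nM to 20000 nM for the coming measurement.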

Compound 3, half-maximal inhibitory concentration: 21500 nM
For compound 3 the middle estimate is 7.2-fold (0.86 log units) below the measured one; measured number outside the range, above it.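

On the shared core, going from 3-(hydroxycarbamoyl)propyl to 5-(hydroxycarbamoyl)pentyl makes no difference that can be read in this assay: a 1.1-fold higher number from compound 1 to compound 3 (0.04 log units; within the scatter). Going by these compounds alone, this is the first comparison of two compounds that differ in one place, and it shows that this added chain length, at this position, brings no gain beyond the usual scatter. Nothing shown here accounts for this result. Still open, on these data alone, is whether a longer chain, or a carboxylic acid in place of the hydroxycarbamoyl end, would shift the number on this core.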